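Series notes: from compound 3 to compound 4

A few compounds are considered here, and "the series" means these few. Any claim that something is new, unique, unknown or untested is made for them only; others in the source may bear on it.

Measured so far, in a functional assay on K562 cells (Homo sapiens) for cytotoxicity, read by sulforhodamine B assay; on this read-out lower numbers stand for stronger inhibition of growth and higher numbers for weaker inhibition of growth:
compound 1 `CC1=CC[C@@H]([C@@](C)(O)CCCC(C)(C)NC(=S)NN)CC1` gives 20 nM;
compound 2 `CC1=CC[C@@H]([C@@](C)(O)CCCC(C)(C)NC(=S)N/N=C\c2ccccc2[N+](=O)[O-])CC1` gives 190 nM;
compound 3 `CC1=CC[C@@H]([C@@](C)(O)CCCC(C)(C)NC(=S)N/N=C\c2cccc([N+](=O)[O-])c2)CC1` gives 20 nM.

Compound 3 stands level with compound 1 at the digits shown, the two together the lowest numbers of the three; compound 2 sits highest, and the step of a 9.5-fold lower number from compound 2 to compound 3 (0.98 log units; beyond the scatter) is the only one among these compounds that lies beyond the scatter.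

Compound 4 `CC1=CC[C@@H]([C@@](C)(O)CCCC(C)(C)NC(=S)N/N=C\c2ccccc2Cl)CC1` is not yet measured. It differs from compound 3 in one place: 2-chlorophenyl in place of 3-nitrophenyl on a carbon with a double bond to nitrogen.

Within the data shown here, only one measured step touches this carbon, a 9.5-fold lower number from compound 2 to compound 3 (0.98 log units; beyond the scatter), and it runs towards the lower number when the nitro group passes from the 2-substituted aryl to the 3-substituted aryl. Among the measured compounds shown here, compound 4 returns a substituent to the 2-position of the aryl but carries chlorine there, and no measured pair shows what chlorine does on this carbon. The expectation therefore leans on that single step and is hedged: a modest rise in the number in this assay is expected, smaller than a 9.5-fold lower number from compound 2 to compound 3 (0.98 log units; beyond the scatter). For the measured compounds named here, that step moved a nitro group, whereas compound 4 brings in chlorine, for which no measured step exists here. For compound 4 the expected value in this assay is 70 nM, with a range from 20 nM to 250 nM, an expected step of a 3.5-fold higher number from compound 3 to compound 4 (0.54 log units; beyond the scatter).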

Compound 4, concentration for 50% growth inhibition: 150 nM
Beside the measured number, compound 4's estimate is 2.1-fold (0.33 log units) below it; low and high end bracket the measured number.
By their numbers in this assay, from the lowest: compounds 1 and 3 (each within the scatter of the next); then compounds 4 and 2 (each within the scatter of the next).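

In this assay, the 2-chlorophenyl group on the carbon with a double bond to nitrogen does not hold the level of the 3-nitrophenyl group, with a 7.5-fold higher number from compound 3 to compound 4 (0.88 log units; beyond the scatter). The earlier compounds left open whether the high number of compound 2 belonged to the nitro group itself, but chloro in place of nitro on the aromatic carbon gives a 1.3-fold lower number from compound 2 to compound 4 (0.10 log units; within the scatter), so in this 2-substituted aryl the two groups cannot be told apart, and among these four compounds the higher numbers fall on the two 2-substituted aryls. The aryl-bearing group on the amide-type nitrogen is thus not neutral in every form: a 7.5-fold higher number from compound 1 to compound 4 (0.88 log units; beyond the scatter) stands against compound 3, which stays level with compound 1 at the digits printed.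

Nothing at hand gives a reason for these differences. Still open, as far as these compounds go, are whether 3-chlorophenyl would match 3-nitrophenyl, which would tie the low number to the 3-substituted aryl rather than to the nitro group, and whether unsubstituted phenyl or 2-aminophenyl would sit with compound 2 and compound 4 or with compound 3.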